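Bromo-to-chloro swap on the oxindole fragment of compound 3

The source may hold more compounds than are shown below. What is called first, only, known or untested is meant among the compounds shown, and "the series" means these compounds.

Measured compounds:
compound 1, `COc1ccc(C2=NN(C3=NC(=O)/C(=C4\C(=O)Nc5ccc(Br)cc54)S3)C(c3ccc(Cl)cc3)C2)cc1`, 370 nM
compound 2, `COc1ccc(C2=NN(C3=NC(=O)/C(=C4\C(=O)Nc5ccc(Cl)cc54)S3)C(c3ccc(Cl)cc3)C2)cc1`, 460 nM
compound 3, `CN(C)c1ccc(C2CC(c3ccccc3)=NN2C2=NC(=O)/C(=C3\C(=O)Nc4ccc(Br)cc43)S2)cc1`, 450 nM

In a functional assay on cells (Cancer cell lines, Homo sapiens) for cytotoxicity, read by sulforhodamine B assay, with a stated time of 48 h (on this read-out lower numbers stand for stronger inhibition of growth and higher numbers for weaker inhibition of growth), compound 1 gives 370 nM and compound 2 gives 460 nM. The two differ by chloro in place of bromo on an aromatic carbon, and the step is a 1.2-fold higher number from compound 1 to compound 2 (0.09 log units; within the scatter). Compound 3 gives 450 nM in this assay; the difference between its core and the core of compound 1 is not broken down here, and all three values lie within the scatter of one another.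

Compound 4, `CN(C)c1ccc(C2CC(c3ccccc3)=NN2C2=NC(=O)/C(=C3\C(=O)Nc4ccc(Cl)cc43)S2)cc1`, has not yet been measured. It differs from compound 3 by chloro in place of bromo on an aromatic carbon, the same change that leads from compound 1 to compound 2, made at the same place. Because compound 1 to compound 2 gave a 1.2-fold higher number from compound 1 to compound 2 (0.09 log units; within the scatter), a step of similar size is expected from compound 3 to compound 4, namely a 1.2-fold higher number from compound 3 to compound 4 (0.06 log units; within the scatter). On that basis compound 4 is estimated to give 520 nM in this assay, with an expected range from 260 nM to 1050 nM.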

Compound 4, concentration for total growth inhibition: 430 nM
Compound 4: the middle estimate sits 1.2-fold (0.08 log units) above what was measured, and the stated range covers the measured number.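

In this assay, chloro in place of bromo on the aromatic carbon gives a 1.0-fold lower number from compound 3 to compound 4 (0.02 log units; within the scatter). Set beside the earlier step, the exchange behaves alike on the core of compound 1 and the core of compound 3, with no difference that can be told apart from the scatter: the same change on two cores in this assay, a 1.2-fold higher number (0.09 log units; within the scatter) from compound 1 to compound 2 and a 1.0-fold lower number (0.02 log units; within the scatter) from compound 3 to compound 4, 1.3-fold (0.11 log units) apart, within the scatter of two such steps This shows that the swap can be carried between these two cores without a detectable change in the number, but it does not show that the change itself has a real effect on either core, and two pairs that both stay within the scatter cannot show that a larger effect of another change would transfer in the same way.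

The compounds shown carry only the two halogens at this place, so it remains open whether fluoro, a methoxy group, an amine or a carboxylic acid there would move the number. As far as these compounds go, it also remains open whether the swap would stay as small on cores with other groups on the remaining aromatic rings.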